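This account rests on a few compounds, and the source may have more. Where it says the series, first, only, none or still open, it means among the compounds named here.

Measured compounds: compound 1, `COc1ccc(N)c(C(=O)CCNC(C)=O)c1`, with 30.7%; compound 2, `COc1ccc(N)c(C(=O)CCNC(=O)C2CCC2)c1`, with 0.01%.

In an assay for inhibition of Nitric oxide synthase, inducible (Homo sapiens), read by scintillation counting, with a stated time of 30 min, tested at 1 mM (on this read-out lower numbers stand for less inhibition and higher numbers for more inhibition at the one concentration tested (going by the name of the read-out)), compound 1 gives 30.7% and stands highest of the two numbers. Its nearest neighbour is compound 2, which gives 0.01%; the step between them is a number 30.7 percentage points lower from compound 1 to compound 2 (beyond the scatter). Compound 3 is `CC(=O)NCCC(=O)c1cc(Cl)ccc1N`. It differs from compound 1 by chloro in place of methoxy on an aromatic carbon. Going by the values given here, the only measured step concerns a group on a carbonyl carbon, not the aromatic ring, so it offers no guide to this change. Among the compounds with values here, with no comparable step, the expectation for compound 3 is a step of a number 5.7 percentage points lower from compound 1 to compound 3 (within the scatter), not beyond the scatter. Compound 3 is therefore estimated at 25%, within 0% to 60%.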

Compound 3, a percentage reported as inhibition, at one concentration (the size of the read-out at that concentration, not a potency): 19.7%
Beside the measured number, compound 3's estimate is 5.3 percentage points above it, and the stated range covers the measured number.
By their numbers in this assay, from the lowest: compound 2; then compound 3; then compound 1.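

Going by these compounds alone, until now only the group on the carbonyl carbon had been varied, so this is the first sign that the aromatic carbon para to an amino group also matters in this assay. Chloro in place of methoxy gives a number 11 percentage points lower from compound 1 to compound 3 (beyond the scatter), and methoxy gives the higher number of the two groups tried at this place. Nothing available explains this step.

On these data alone, whether a smaller halogen such as fluoro, a hydroxyl or a plain hydrogen would give a higher number at this place stays open. So does the effect of chloro with the cyclobutyl group in place of methyl.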